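Ring-for-chain exchange on the hydroxy acyl side chain

The source may hold more compounds than are shown below. What is called first, only, known or untested is meant among the compounds shown, and "the series" means these compounds.

Measured in an ADME assay on Caco-2 cells (Homo sapiens) for permeability, read by LC-MS, in the apical to basolateral direction, with a stated time of 60 min, at pH 6.5; a higher number here means that the compound crosses the layer faster, a lower number that the compound crosses the layer more slowly:
compound 1, `COC(C)(C)[C@@H](O)C(=O)N1[C@H](C(=O)NCc2cc(Cl)ccc2-n2cnnn2)C[C@@H]2C[C@@H]21`, compound 1 gives 16 10^-6 cm/s
compound 2, `CCCC[C@@H](O)C(=O)N1N=CC[C@H]1C(=O)NCc1cc(Cl)ccc1-n1cnnn1`, compound 2 gives 9.8 10^-6 cm/s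
compound 3, `O=C(O[C@@H](C(=O)N1N=CC[C@H]1C(=O)NCc1cc(Cl)ccc1-n1cnnn1)c1ccc(F)cc1)c1ccccc1`, compound 3 gives 43 10^-6 cm/s

Compound 2 holds the smallest of the three numbers in this assay, but its number and that of compound 1 lie within the usual scatter of each other, so no order between these two can be read. Compound 3, by contrast, sits beyond the scatter, with a clearly higher number than compound 2.

Compound 4, `CC1(C[C@@H](O)C(=O)N2N=CC[C@H]2C(=O)NCc2cc(Cl)ccc2-n2cnnn2)CC1`, shares everything with compound 2 except one group: 1-methylcyclopropyl in place of propyl on a saturated chain carbon, two bonds along the chain from a carbonyl carbon and an oxygen on a saturated carbon. The leaving and entering groups are both saturated carbon fragments without donors, acceptors or charge, and the change is one heavy atom in size. Going by the values given here, no measured pair shows this kind of exchange, so the step rests on compound 2 alone. Compound 4 is expected to give 12 10^-6 cm/s in this assay, with a range from 6 10^-6 cm/s to 24 10^-6 cm/s. The estimated step of a 1.2-fold higher number from compound 2 to compound 4 (0.09 log units; within the scatter) is expected to remain within the scatter, leaning slightly upward.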

Compound 4, apparent permeability: 9.5 10^-6 cm/s
Beside the measured number, compound 4's estimate is 1.3-fold (0.10 log units) above it; the measured number falls inside the stated range.
By their numbers in this assay, from the lowest: compounds 4, 2 and 1 (each within the scatter of the next); then compound 3.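

Going by these compounds alone, replacing propyl with 1-methylcyclopropyl on a saturated chain carbon, two bonds along the chain from a carbonyl carbon and an oxygen on a saturated carbon, gives a 1.0-fold lower number from compound 2 to compound 4 (0.01 log units; within the scatter) in this assay, the first step that can be read at this position. The end of this side chain can therefore carry a three-membered carbon ring and one more heavy atom with the number staying within the scatter, at least for this single pair. Nothing measured here gives a reason for this outcome.

On these data alone, it remains open whether an amine, a carboxylic acid or a longer chain at this position would also stay within the scatter. Compounds 1 and 3 differ from compound 2 in more than one place, so the higher number of compound 3 cannot be assigned to any single change.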